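This account rests on a few compounds, and the source may have more. Where it says the series, first, only, none or still open, it means among the compounds named here.

Of the compounds shown here, three built on one shared core have been tested in a functional assay on DU-145 cells (Homo sapiens) for cytotoxicity, read by MTT assay; on this read-out lower numbers stand for stronger inhibition and higher numbers for weaker inhibition. Compound 1 `CC(C)=CC[C@@H](OCC(C)O)C1=CC(=O)c2c(O)ccc(O)c2C1=O` gives 16100 nM in this assay. Compound 2 `CC(C)=CC[C@@H](OC(=O)CC(O)c1ccccc1)C1=CC(=O)c2c(O)ccc(O)c2C1=O` gives 17000 nM, and compound 3 `CC(C)=CC[C@@H](OC(=O)C1CCCOC1)C1=CC(=O)c2c(O)ccc(O)c2C1=O` gives 29700 nM. Of the three numbers, that of compound 1 is the lowest, yet the gap to compound 2 and the gap to compound 3 both lie within the scatter of repeated measurements, so the three compounds cannot really be told apart on these data.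

Compound 4 `CCC(O)(CC)CC(=O)O[C@H](CC=C(C)C)C1=CC(=O)c2c(O)ccc(O)c2C1=O` differs from compound 1 at a single site: (2-ethyl-2-hydroxybutyl)carbonyl in place of 2-hydroxypropyl on an oxygen on a saturated carbon. The most relevant earlier step is a 1.8-fold higher number from compound 1 to compound 3 (0.27 log units; within the scatter), where an (oxan-3-yl)carbonyl group took the place of the same 2-hydroxypropyl group at the same oxygen and the number barely moved. The step of a 1.7-fold higher number from compound 2 to compound 3 (0.24 log units; within the scatter), which swaps one carbonyl-bound group for another, was likewise within the scatter. Both steps suggest that changing what hangs on this oxygen, whether by an ether-type or a carbonyl-type link, leaves this assay largely unaffected, so for compound 4 no step beyond the scatter is expected in either direction, meaning an expected change of a 1.2-fold higher number from compound 1 to compound 4 (0.09 log units; within the scatter). Compound 4 is therefore estimated at 20000 nM, with a likely range from 9000 nM to 45000 nM.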

Compound 4, half-maximal inhibitory concentration: 67000 nM
Compound 4: the middle estimate sits 3.4-fold (0.53 log units) below what was measured; the measured number lies above the stated range.
By their numbers in this assay, from the lowest: compounds 1, 2 and 3 (each within the scatter of the next); then compound 4.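

In this assay, this oxygen on a saturated carbon turns out not to be indifferent to what it carries: the earlier swaps stayed within the scatter, but (2-ethyl-2-hydroxybutyl)carbonyl in place of 2-hydroxypropyl gives a 4.2-fold higher number from compound 1 to compound 4 (0.62 log units; beyond the scatter) and so weaker inhibition, a modest change. The carbonyl link alone does not set compound 4 apart, for compounds 2 and 3 carry it too, and the groups on that carbonyl still separate them, with a 2.3-fold higher number from compound 3 to compound 4 (0.35 log units; beyond the scatter) and a 3.9-fold higher number from compound 2 to compound 4 (0.60 log units; beyond the scatter) both beyond the scatter. No measurement at hand gives a reason for this loss.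

From the compounds shown here alone, what remains open is which part of the entering group goes with the weaker inhibition, the two ethyl branches or the hydroxy group, and a 2-hydroxy-2-methylpropyl group on the same carbonyl, or a 2-ethylbutyl group without the hydroxy, would help separate the two. Going by these compounds, it is also open whether an amine in place of that hydroxy, or a longer chain on the carbonyl, would move the number further or bring it back towards that of compound 1.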